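The source may report more compounds than this note shows. Statements on the series, on what has been measured and on what is new or still open speak of the compounds shown alone.

Working notes on the series sharing the core of compound 1 `COc1ccccc1-c1cnc(C(=O)CCCCCCc2ccccc2)o1`, which in an assay (Rattus norvegicus) for inhibition of Fatty-acid amide hydrolase 1 (Homo sapiens) (a lower number here means a stronger inhibitor, a higher number a weaker inhibitor), gives 400 nM. Compound 2 `Nc1cccc(-c2cnc(C(=O)CCCCCCc3ccccc3)o2)c1` gives 19 nM in this assay, and compound 3 `Cc1cccnc1-c1cnc(C(=O)CCCCCCc2ccccc2)o1` gives 15 nM. On these three numbers compound 2 stands second highest: its nearest neighbour is compound 3, at a distance within the scatter, while compound 1 is furthest away, a step beyond the scatter.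

The next compound is compound 4 `Cc1ccc(-c2cnc(C(=O)CCCCCCc3ccccc3)o2)nc1`. The change from compound 2 is 5-methylpyridin-2-yl in place of 3-aminophenyl on an aromatic carbon.

Two measured steps speak to the weight of the aryl group at this place: a 21-fold lower number from compound 1 to compound 2 (1.32 log units; beyond the scatter) and a 27-fold lower number from compound 1 to compound 3 (1.43 log units; beyond the scatter), both large. Between the two groups that gave these large steps the difference is small: a 1.3-fold lower number from compound 2 to compound 3 (0.10 log units; within the scatter), within the scatter. Compound 4 carries a pyridin-2-yl group as compound 3 does, but as 5-methylpyridin-2-yl rather than 3-methylpyridin-2-yl. For the measured compounds named here, no measured step tests this methyl shift directly, so the step from compound 2 to compound 4 in this assay is expected to be a 1.1-fold lower number from compound 2 to compound 4 (0.02 log units; within the scatter), that is, none beyond the scatter. Compound 4 is estimated at 18 nM, with a range from 7 nM to 50 nM.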

Compound 4, inhibition constant: 2.8 nM
Estimate against measurement, compound 4: 6.4-fold (0.81 log units) above, outside the stated range (below it).
By their numbers in this assay, from the lowest: compound 4; then compounds 3 and 2 (each within the scatter of the next); then compound 1.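

The methyl shift on the pyridin-2-yl group now has a measured size in this assay: moving from 3-methylpyridin-2-yl to 5-methylpyridin-2-yl gives a 5.4-fold lower number from compound 3 to compound 4 (0.73 log units; beyond the scatter) and so matters at this aromatic carbon next to the ring oxygen, where compounds 2 and 3 alone had suggested that different aryl groups might give much the same number. The new group also separates from 3-aminophenyl, with a 6.8-fold lower number from compound 2 to compound 4 (0.83 log units; beyond the scatter) showing that the two groups of equal heavy-atom count are not interchangeable here, and the span of the series grows to a 140-fold lower number from compound 1 to compound 4 (2.15 log units; beyond the scatter), which makes compound 4 the strongest inhibitor of the four, since its steps to all the others lie beyond the scatter. Nothing at hand accounts for the gain from moving the methyl.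

From the compounds shown here alone, whether an amine, a carboxylic acid or a longer chain in place of the methyl of 5-methylpyridin-2-yl would keep this number stays open. Also open, going by these compounds, is where the unsubstituted pyridin-2-yl group would fall relative to compound 3 and compound 4, and so whether the methyl of compound 4 adds to the number or the methyl of compound 3 takes away from it.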